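This account rests on a few compounds, and the source may have more. Where it says the series, first, only, none or still open, it means among the compounds named here.

Compound 3 `C=CCN(C)C(=O)c1ccc(C(CC)(CC)c2ccc(OCCC(O)(CC)CC)c(C)c2)n1CC` is one of three measured members of a shared core; its own result in an assay on cells for agonist activity at vitamin D3 receptor (Homo sapiens), with a stated time of 96 h (a lower number here means that less compound is needed, a higher number that more compound is needed for the effect), is a limit of the assay, > 10000 nM, and so it is only known to sit at the limit of > 10000 nM in this assay, at which 2 of the 3 values shown sit. Compound 2 `CCn1c(C(=O)N(CCC#N)CCC#N)ccc1C(CC)(CC)c1ccc(OCCC(O)(CC)CC)c(C)c1` likewise gives only a limit, > 10000 nM. Compound 1 `CCn1c(C(=O)NCC#N)ccc1C(CC)(CC)c1ccc(OCCC(O)(CC)CC)c(C)c1`, whose carbonyl carbon carries (cyanomethyl)amino, gives 1080 nM in this assay. The two readable steps, an at least 9.2-fold higher number from compound 1 to compound 2 (0.96 log units; beyond the scatter) and an at least 9.2-fold higher number from compound 1 to compound 3 (0.96 log units; beyond the scatter), both run from the (cyanomethyl)amino compound to the limit, while a step that the two limits leave unreadable from compound 2 to compound 3. Compound 4 `CCn1c(C(=O)Nc2ccc(OC(F)(F)F)cc2)ccc1C(CC)(CC)c1ccc(OCCC(O)(CC)CC)c(C)c1` arises from compound 3 by (4-(trifluoromethoxy)phenyl)amino in place of allyl(methyl)amino on a carbonyl carbon. For the measured compounds named here, no measured step carries an aryl group on this amide, so the expectation rests on compound 1, which with its (cyanomethyl)amino amide gave 1080 nM. The step of an at least 16-fold lower number from compound 3 to compound 4 (1.22 log units; beyond the scatter) is expected to be a fall, of a size that cannot be read exactly. For compound 4 the estimated value in this assay is 600 nM, expected to fall between 100 nM and 5000 nM.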

Compound 4, half-maximal effective concentration: > 10000 nM
Compound 4 ended at the assay's limit; the forecaster's own chance of this, stated with the estimate: 20%; middle value at least 16-fold (1.22 log units) away from the limit.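

For the compounds shown here, until now the only compounds at the limit, compound 2 and compound 3, both lacked the amide hydrogen that compound 1 carries. Compound 4 keeps that hydrogen, yet with 4-(trifluoromethoxy)phenyl in place of cyanomethyl on the amide-type nitrogen there is an at least 9.2-fold higher number from compound 1 to compound 4 (0.96 log units; beyond the scatter) in this assay, so the amide hydrogen alone does not preserve the activity of compound 1. The steps among compound 2, compound 3 and compound 4 cannot be read, as all three results are limits and not numbers: the limit of > 10000 nM in this assay, at which 3 of the 4 values shown sit.

Going by these compounds alone, compound 1, at 1080 nM, remains the only member with a measured number, so how much change this amide accepts is still unknown. On these data alone, whether a plain ethylamide or a benzylamide would give a number here, and whether an unsubstituted phenyl would behave like compound 4, stays open.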